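The source may report more compounds than this note shows. Statements on the series, on what has been measured and on what is new or still open speak of the compounds shown alone.

Compound 1 `Cc1ccccc1CN1CCc2c(sc(NC(=O)c3ccccc3Cl)c2C(N)=O)C1` in a functional assay on HL-60 cells (Homo sapiens) for antiproliferative activity, with a stated time of 24 h (on this read-out higher numbers stand for weaker inhibition and lower numbers for stronger inhibition), sits at the assay limit of > 50000 nM. Compound 2 `N#Cc1ccccc1CN1CCc2c(sc(NC(=O)c3ccccc3Cl)c2C(N)=O)C1` gives 10400 nM. Compound 3 `NC(=O)c1c(NC(=O)c2ccccc2Cl)sc2c1CCN(Cc1ccc(Cl)cc1)C2` gives 22500 nM.

Of the two values that are numbers rather than limits, compound 3 holds the higher one; its nearest neighbour is compound 2, and the step of a 2.2-fold higher number from compound 2 to compound 3 (0.34 log units; beyond the scatter) lies beyond the usual scatter. The third value, that of compound 1, is a limit only (the limit of > 50000 nM in this assay, at which 1 of the 3 values shown sits). From compound 1 the step of an at least 2.2-fold lower number from compound 1 to compound 3 (0.34 log units; beyond the scatter) is at least modest, and the step of an at least 4.8-fold lower number from compound 1 to compound 2 (0.68 log units; beyond the scatter) is larger.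

Compound 4 `NC(=O)c1c(NC(=O)c2ccccc2Cl)sc2c1CCN(C(=O)Nc1ccccc1Cl)C2` differs from compound 3 in one place: (2-chlorophenyl)carbamoyl in place of 4-chlorobenzyl on an amine nitrogen in a ring. Among the compounds with values here, no measured step makes a change of this kind. The two steps into compound 3 swap one aryl group for another on the same benzyl carbon, and the step between compound 1 and compound 2 alters a substituent on that aryl ring; all three keep a benzyl group on the ring nitrogen, whereas compound 4 replaces it with a carbamoyl carrying its own aryl group. The measured steps therefore give no direction for this change, and the step of a 1.3-fold lower number from compound 3 to compound 4 (0.10 log units; within the scatter) is expected to be of no clear size beyond the scatter, with a wide range around it. Compound 4 is estimated at 18000 nM in this assay, between 5000 nM and 50000 nM.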

Compound 4, half-maximal inhibitory concentration: 12500 nM
For compound 4 the middle estimate is 1.4-fold (0.16 log units) above the measured one; low and high end bracket the measured number.
By their numbers in this assay, from the lowest: compounds 2, 4 and 3 (each within the scatter of the next, the first and the last beyond it). At a limit, above all of these: compound 1.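

In this assay, within the data shown here, the earlier compounds carried only benzyl groups on the amine nitrogen in a ring, and compound 4 shows that a (2-chlorophenyl)carbamoyl group can take that place with no change beyond the scatter: a 1.8-fold lower number from compound 3 to compound 4 (0.26 log units; within the scatter), and a 1.2-fold higher number from compound 2 to compound 4 (0.08 log units; within the scatter). The swap therefore adds a carbonyl and a hydrogen-bond donor at this position, yet the read-out stays level with both the 4-chlorobenzyl and the 2-cyanobenzyl compounds, so the benzyl carbon is not required for this level of activity among the compounds shown. Only the 2-methylbenzyl compound stands apart, with an at least 4.0-fold lower number from compound 1 to compound 4 (0.60 log units; beyond the scatter), and compound 1 gives a limit rather than a number, so that step has no exact size: the limit of > 50000 nM in this assay, at which 1 of the 4 values shown sits.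

The compounds shown leave open whether the carbamoyl link or its chlorophenyl group matters more at this nitrogen, as every group there still carries an aromatic ring; a simple acetyl group or an aminoethyl chain would test this. They also leave open how the read-out would respond to a carboxylic acid in place of the primary amide on the shared core.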